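Swapping the aryl group on a hydrazone linker

The compounds below may be only part of what the source reports. "The series", "measured", "known", "first", "only" and "open" are said of these compounds alone.

Measured compounds in an ADME assay on THP-1 cells (Homo sapiens) for cytotoxicity; on this read-out lower numbers stand for stronger inhibition and higher numbers for weaker inhibition:
compound 1, `COc1ccccc1-c1nnc(-c2ccc(C(=O)N/N=C/c3ccncc3)cc2)o1`, giving 173000 nM
compound 2, `COc1ccccc1-c1nnc(-c2ccc(C(=O)N/N=C/c3cccnc3)cc2)o1`, giving 167000 nM
compound 3, `COc1ccccc1-c1nnc(-c2ccc(C(=O)N/N=C/c3cccc(O)c3O)cc2)o1`, giving 102000 nM

These three compounds share one core and differ only in the aryl group attached to the carbon that carries a double bond to nitrogen. Compound 3 sits at the low end of the three numbers, yet the steps that separate it from the others are small: a 1.7-fold lower number from compound 1 to compound 3 (0.23 log units; within the scatter) and a 1.6-fold lower number from compound 2 to compound 3 (0.21 log units; within the scatter), both within the scatter, so the three compounds cannot be told apart with confidence.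

Compound 4, `COc1ccc(/C=N/NC(=O)c2ccc(-c3nnc(-c4ccccc4OC)o3)cc2)cc1O`, has not been measured. It differs from compound 3 in one place: 3-hydroxy-4-methoxyphenyl in place of 2,3-dihydroxyphenyl on a carbon with a double bond to nitrogen. The steps that speak to this change are the two aryl swaps at the same position, from compound 1 to compound 3 and from compound 2 to compound 3, and neither of them moved the number beyond the scatter. Exchanging one hydroxylated phenyl ring for another is therefore expected to leave the read-out essentially where it is, with a 1.2-fold higher number from compound 3 to compound 4 (0.07 log units; within the scatter) as the expected step. Compound 4 is accordingly estimated at 120000 nM, within a range from 60000 nM to 240000 nM.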

Compound 4, half-maximal inhibitory concentration: 260000 nM
Compound 4: the middle estimate sits 2.2-fold (0.34 log units) below what was measured, outside the stated range (above it).
By their numbers in this assay, from the lowest: compounds 3, 2, 1 and 4 (each within the scatter of the next, the first and the last beyond it).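

In this assay, going by these compounds alone, no earlier swap at this position had produced a step beyond the scatter, so a 2.5-fold higher number from compound 3 to compound 4 (0.41 log units; beyond the scatter) is the first to do so, though the step is modest. Two phenyl rings that both carry a hydroxy group can therefore read differently on this carbon, even though the step is no larger than this. Yet a 1.6-fold higher number from compound 2 to compound 4 (0.19 log units; within the scatter) and a 1.5-fold higher number from compound 1 to compound 4 (0.18 log units; within the scatter) both lie within the scatter, so 3-hydroxy-4-methoxyphenyl can be told apart from 2,3-dihydroxyphenyl but from neither pyridinyl group, and nothing available explains the one step that does stand out.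

Going by these compounds, the swap changes several things together, going from 2 hydrogen-bond donors to 1 hydrogen-bond donor and adding a methoxy group, and whether the methoxy group or the arrangement of the hydroxy groups accounts for the gap remains open. Also open, on these data alone, is how a plain phenyl ring, or a phenyl ring bearing an amine or a carboxylic acid, would read on this carbon.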